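Fluorine Added to a Series Without Measurable Response

This account rests on a few compounds, and the source may have more. Where it says the series, first, only, none or still open, it means among the compounds named here.

Three compounds of a shared core were tested in a functional assay on HEK293 cells for agonist activity at Glucose-dependent insulinotropic receptor (Homo sapiens), read by cAMP accumulation, with a stated time of 60 min; on this read-out higher numbers stand for an effect only at larger amounts of compound and lower numbers for an effect already at smaller amounts. Compound 1 `COc1cc2nc(N3CCC4CCC(C3)N4Cc3ccccc3)nc(Nc3ccc(S(C)(=O)=O)cc3F)c2cc1OC` gives > 10000 nM, which is a limit of the assay rather than a number. Compound 2 `COc1cc2nc(Nc3ccc(S(C)(=O)=O)cc3F)nc(OCC3CCN(C(=O)OC(C)(C)C)CC3)c2cc1OC` likewise gives > 10000 nM, again only a limit. Compound 3 `COc1cc2nc(Nc3ccc(S(C)(=O)=O)cc3)nc(OC3CCN(C(=O)OC(C)(C)C)CC3)c2cc1OC`, the starting point of the step followed here, gives > 10000 nM, also a limit. Among the compounds with values here, all three values sit at the limit of > 10000 nM in this assay, at which 3 of the 3 values shown sit, so compound 3 stands nowhere in particular on these numbers: it is indistinguishable from the other two, and no measured step between any pair can be drawn.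

Compound 4 `COc1cc2nc(Nc3ccc(S(C)(=O)=O)cc3F)nc(OC3CCN(C(=O)OC(C)(C)C)CC3)c2cc1OC` has not yet been measured. It differs from compound 3 by fluoro in place of hydrogen on an aromatic carbon. Within the data shown here, compound 2 already carries the fluoro group on the same ring, and compound 2 gave only a limit, though its side chain differs from that of compound 3 and no step is counted between them. Since no response appears at any tested amount, the estimated step of a number no higher from compound 3 to compound 4 (the limit leaves the size open) is none beyond the scatter. Compound 4 is accordingly expected near 10000 nM, between 3000 nM and 30000 nM, in this assay, most likely reported once more only as a limit.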

Compound 4, half-maximal effective concentration: > 10000 nM
Compound 4: a limit, no number; the forecaster's own chance of this, stated with the estimate: 85%; the middle value lies on the limit itself.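

In this assay compound 4 gives > 10000 nM, which is a limit and not a number. Within the data shown here, compound 3 sits at the same limit, so no step between compound 3 and compound 4 can be read: the limit of > 10000 nM in this assay, at which 4 of the 4 values shown sit. The compounds shown leave open whether fluoro in place of hydrogen on this aromatic carbon changes the response at all.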